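Butyl in place of chloro on compound 3

The source may report more compounds than this note shows. Statements on the series, on what has been measured and on what is new or still open speak of the compounds shown alone.

Values in an ADME assay on J774 cells (Mus musculus) for cytotoxicity, read by MTT assay, with a stated time of 48 h (on this read-out higher numbers stand for weaker inhibition and lower numbers for stronger inhibition), so far
compound 1 `O=C(N/N=C/c1ccc([N+](=O)[O-])o1)c1ccc([N+](=O)[O-])cc1` gives 79100 nM
compound 2 `CCCCc1ccc(C(=O)N/N=C/c2ccc([N+](=O)[O-])o2)cc1` gives 28100 nM
compound 3 `CC(=O)N1N=C(c2ccc(Cl)cc2)OC1c1ccc([N+](=O)[O-])o1` gives > 400000 nM as a limit, not a number

Compound 3 sits at the limit of > 400000 nM in this assay, at which 1 of the 3 values shown sits, and so is known only as a limit. The next compound to read is compound 4 `CCCCc1ccc(C2=NN(C(C)=O)C(c3ccc([N+](=O)[O-])o3)O2)cc1`, which keeps the core of compound 3 and changes one group: butyl in place of chloro on an aromatic carbon, para to a large group.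

Going by the values given here, one measured step bears on this change: a 2.8-fold lower number from compound 1 to compound 2 (0.45 log units; beyond the scatter). That step also brings in butyl on an aromatic carbon, but it replaces nitro rather than chloro and sits on the core of compound 1, so it transfers only loosely. With a single modest step as a guide and only a limit as the starting point, the size of the new step stays uncertain, and compound 4 may also report only as a limit. A modest move towards a lower number in this assay is expected, and the step is estimated as an at least 2.2-fold lower number from compound 3 to compound 4 (0.34 log units; beyond the scatter) (a rough figure, given the limit). For compound 4 the estimated value is 180000 nM (expected range 60000 nM to 400000 nM).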

Compound 4, half-maximal inhibitory concentration: > 400000 nM
Compound 4: no number, only a limit; the forecaster's own chance of this, stated with the estimate: 30%; at least 2.2-fold (0.34 log units) between middle value and limit.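

In this assay compound 4 gives > 400000 nM, a limit and not a number, and with compound 3 also known only as a limit, no step between the two can be read: the limit of > 400000 nM in this assay, at which 2 of the 4 values shown sit.

The compounds shown leave open whether butyl in place of chloro changes the value on the core of compound 3 at all.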